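The compounds below may be only part of what the source reports. "The series", "measured", "known", "first", "only" and "open" are said of these compounds alone.

Two compounds of this series have been run in an in vivo functional assay on the whole organism (heart) with Rattus norvegicus as the target; on this read-out higher numbers stand for an effect only at larger amounts of compound and lower numbers for an effect already at smaller amounts. Compound 1 `O=C1NC(c2ccccc2)=C([N+](=O)[O-])C(c2cccc([N+](=O)[O-])c2)N1` gives 0.000045 mg/kg. Compound 2 `O=C1NC(c2ccccc2)=C([N+](=O)[O-])C(c2cccs2)N1` gives 3.5 mg/kg. On these two numbers compound 2 stands at the higher end: its value is far above that of compound 1, and the gap between the two lies well beyond the scatter of this kind of measurement. Among the measured compounds shown here, no step between compounds that differ in only one place has been measured, so the two values can only be compared as they stand.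

Compound 3 `O=C1NC(c2ccccc2)=C([N+](=O)[O-])C(c2cccnc2)N1` has not yet been measured in this assay. It differs from compound 2 in one place: pyridin-3-yl in place of thiophen-2-yl on a saturated ring carbon. The group that leaves and the group that enters each carry one hydrogen-bond acceptor and no net charge.

For the measured compounds named here, for compound 3 a step of a 4.4-fold lower number from compound 2 to compound 3 (0.64 log units; beyond the scatter) is expected, toward a lower number, because compound 2 sits at the high end with 3.5 mg/kg and the only other member, compound 1, lies so far below it. The size of that step is uncertain with two points only. Compound 3 is estimated at 0.8 mg/kg, within a range from 0.005 mg/kg to 20 mg/kg.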

Compound 3, minimum effective dose: 0.035 mg/kg
Estimate against measurement, compound 3: 23-fold (1.36 log units) above; measured number inside the range.
By their numbers in this assay, from the lowest: compound 1; then compound 3; then compound 2.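

In this assay, among the compounds shown here, a 100-fold lower number from compound 2 to compound 3 (2.00 log units; beyond the scatter) is the first step between compounds that differ in one place, and it shows that the read-out depends strongly on which aromatic ring sits on this saturated ring carbon. The change swaps a five-membered aromatic ring for a six-membered one, each with 1 hetero atom and with the same counts of hydrogen-bond donors and acceptors, so those matching counts do not keep the read-out at the same level at this position. No measured property of these compounds bears on the size of this step.

Compound 3 at 0.035 mg/kg still has a higher number than compound 1 at 0.000045 mg/kg, and the compounds shown leave open how the aromatic group of compound 1 relates to the other two. They also leave open whether the ring nitrogen of pyridin-3-yl or the ring size carries the step, a question that an unsubstituted phenyl or a furan ring on the same carbon of the shared core would address.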